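Shortening the Side Chain of Compound 3

This account rests on a few compounds, and the source may have more. Where it says the series, first, only, none or still open, it means among the compounds named here.

Three compounds share one core and differ only in the group attached to one aromatic carbon. Compound 1 `COc1nc2ccc(Br)cc2cc1C(c1ccccc1)n1cc(-c2ccccc2)nn1` carries a phenyl there, and in an ADME assay on PC-3 cells (Homo sapiens) for cytotoxicity, read by sulforhodamine B assay, with a stated time of 48 h, tested at 10 uM (a higher number here means more inhibition at the concentration tested (going by the name of the read-out), a lower number less inhibition), compound 1 gives 5.97%. Compound 2 `CCCCc1cn(C(c2ccccc2)c2cc3cc(Br)ccc3nc2OC)nn1` carries a butyl in that place, and compound 2 gives 5.54%. Compound 3 `CCCCCc1cn(C(c2ccccc2)c2cc3cc(Br)ccc3nc2OC)nn1` carries a pentyl, and compound 3 gives 11.4%. Compound 3 thus holds the highest of the three numbers, yet a number 5.4 percentage points higher from compound 1 to compound 3 (within the scatter) and a number 5.9 percentage points higher from compound 2 to compound 3 (within the scatter) both lie within the scatter, so the three numbers are level and none can be said to be higher than another. Compound 4 `CCCc1cn(C(c2ccccc2)c2cc3cc(Br)ccc3nc2OC)nn1` is compound 3 with a shorter chain: hydrogen in place of ethyl on a saturated chain carbon, three bonds along the chain from an aromatic carbon. The step that bears most on this change is a number 5.9 percentage points higher from compound 2 to compound 3 (within the scatter), where one carbon was added to the chain; here two carbons are taken away. Neither that step nor a number 0.4 percentage points lower from compound 1 to compound 2 (within the scatter) moved the read-out beyond the scatter, so no step beyond the scatter is expected from this change either. Compound 4 is therefore expected to give about 7%, between 0% and 16%, which would mean an expected step of a number 4.4 percentage points lower from compound 3 to compound 4 (within the scatter).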

Compound 4, a percentage reported as inhibition, at one concentration (the size of the read-out at that concentration, not a potency): 8.3%
The estimate for compound 4 lay 1.3 percentage points below the measured number; the range from low to high includes it.
By their numbers in this assay, from the lowest: compounds 2, 1, 4 and 3 (each within the scatter of the next).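

In this assay, cutting the pentyl back to propyl gives a number 3.1 percentage points lower from compound 3 to compound 4 (within the scatter) and leaves the read-out where it was, and the same holds against the butyl, with a number 2.8 percentage points higher from compound 2 to compound 4 (within the scatter) as the step. Putting propyl in place of phenyl on the aromatic carbon gives a number 2.3 percentage points higher from compound 1 to compound 4 (within the scatter) and so adds a third chain length that stands level with the phenyl, which means that propyl, butyl, pentyl and phenyl cannot be told apart at this position in this read-out. No further measurement offers an account of this flat result.

As far as these compounds go, what stays open is whether a much longer chain, such as decyl, would lift the number beyond the scatter. An amine or a carboxylic acid at the end of the chain is equally untested by these compounds.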